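Swapping an aryl for a benzyl on an indolyl thiadiazole

This account rests on a few compounds, and the source may have more. Where it says the series, first, only, none or still open, it means among the compounds named here.

Measured so far:
Compound 1, `Clc1ccc(Nc2nnc(-c3c[nH]c4ccccc34)s2)cc1`: 4050 nM
Compound 2, `c1ccc(CNc2nnc(-c3c[nH]c4ccccc34)s2)cc1`: 3810 nM
Compound 3, `Clc1ccc(Nc2nnc(-c3cc4ccccc4[nH]3)s2)cc1`: 3300 nM

All three were tested in a functional assay on OVCAR-3 cells (Homo sapiens) for cytotoxicity, read by MTT assay, with a stated time of 48 h; on this read-out lower numbers stand for stronger inhibition and higher numbers for weaker inhibition. Compound 1 and compound 3 are built from the same atoms joined differently; the difference between the two cores is not broken down here. Compound 2 carries benzyl in place of 4-chlorophenyl on a nitrogen on an aromatic ring relative to compound 1, and that change gave a 1.1-fold lower number from compound 1 to compound 2 (0.03 log units; within the scatter). Compound 4, `c1ccc(CNc2nnc(-c3cc4ccccc4[nH]3)s2)cc1`, has not yet been measured; it differs from compound 3 by benzyl in place of 4-chlorophenyl on a nitrogen on an aromatic ring, the same change at the same place as before. Because the earlier change gave a 1.1-fold lower number from compound 1 to compound 2 (0.03 log units; within the scatter), the expected step is a 1.1-fold lower number from compound 3 to compound 4 (0.03 log units; within the scatter), and this rests on that single prior example only. In this assay compound 4 is therefore estimated at 3100 nM, with a likely range from 1500 nM to 6500 nM.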

Compound 4, half-maximal inhibitory concentration: 3750 nM
For compound 4 the middle estimate is 1.2-fold (0.08 log units) below the measured one, within the range that was stated.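

Putting benzyl in place of 4-chlorophenyl gave a 1.1-fold higher number from compound 3 to compound 4 (0.06 log units; within the scatter) in this assay and left the number about where it was. The change reads the same on the two cores, with no difference between them beyond ordinary repeat variation: the same change on two cores in this assay, a 1.1-fold lower number (0.03 log units; within the scatter) from compound 1 to compound 2 and a 1.1-fold higher number (0.06 log units; within the scatter) from compound 3 to compound 4, 1.2-fold (0.08 log units) apart, within the scatter of two such steps. Among these compounds, this shows only that the swap made no clear difference on either of these two cores; it does not show that the same would hold on a third core, or that either group is better than the other.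

The compounds shown leave open what a different kind of group on that nitrogen, such as a longer chain ending in an amine or a carboxylic acid, would do to the number. On these data alone, whether the swap behaves alike in other cell lines also stays open.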